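The source may report more compounds than this note shows. Statements on the series, on what has been measured and on what is new or still open speak of the compounds shown alone.

Compound 3 `Cc1cc(S(=O)(=O)/N=C(\N)n2nccc2-c2ccccc2)c(SCc2cccc3ccccc23)cc1Cl` shares its core with compound 1 `Cc1cc(S(=O)(=O)/N=C(\N)n2nccc2-c2ccccc2)c(SCc2cccc(Cl)c2)cc1Cl` and compound 2 `Cc1cc(S(=O)(=O)/N=C(\N)n2nccc2-c2ccccc2)c(SCc2ccccc2)cc1Cl`; the three differ only in the group carried on the saturated chain carbon bound to a sulfur. In a functional assay on HCT-116 cells (Homo sapiens) for cytotoxicity, read by MTT assay, with a stated time of 72 h (on this read-out lower numbers stand for stronger inhibition and higher numbers for weaker inhibition), compound 3 gives 7000 nM, compound 1 gives 7000 nM and compound 2 gives 12000 nM. On these numbers compound 3 sits alongside compound 1, since no change at the digits printed from compound 1 to compound 3 (within the scatter), and its separation from compound 2 is likewise small, as a 1.7-fold lower number from compound 2 to compound 3 (0.23 log units; within the scatter). The whole set spans a narrow band: a 1.7-fold higher number from compound 1 to compound 2 (0.23 log units; within the scatter).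

Compound 4 `Cc1cc(S(=O)(=O)/N=C(\N)n2nccc2-c2ccccc2)c(SCc2ccccc2C)cc1Cl` is reached from compound 3 by a change at that same position: 2-methylphenyl in place of naphthalen-1-yl on a saturated chain carbon bound to a sulfur. Going by the values given here, the steps that bear on it are those at this carbon, from compound 2 to compound 3 and from compound 1 to compound 3, and both stayed within the scatter, as did the exchange of chloro for hydrogen from compound 1 to compound 2. Nothing in the measured set points to a shift beyond the scatter in this assay in either direction.

Compound 4 is therefore expected to give about 9000 nM in this assay, within a range of 4000 nM to 20000 nM. The step this estimate implies is a 1.3-fold higher number from compound 3 to compound 4 (0.11 log units; within the scatter).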

Compound 4, half-maximal inhibitory concentration: 16000 nM
Compound 4: the middle estimate sits 1.8-fold (0.25 log units) below what was measured, and the stated range covers the measured number.
By their numbers in this assay, from the lowest: compounds 1, 3, 2 and 4 (each within the scatter of the next, the first and the last beyond it).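

Going by these compounds alone, at the saturated chain carbon bound to a sulfur, the change to 2-methylphenyl gives the first steps beyond the scatter in this assay, though both are modest: one replaces naphthalen-1-yl (a 2.3-fold higher number from compound 3 to compound 4 (0.36 log units; beyond the scatter)) and the other replaces 3-chlorophenyl (a 2.3-fold higher number from compound 1 to compound 4 (0.36 log units; beyond the scatter)). Within the data shown here, the added methyl on an aromatic carbon does not set compound 4 apart from compound 2 (a 1.3-fold higher number from compound 2 to compound 4 (0.12 log units; within the scatter)), so this position now shows a modest separation only for some pairs, with compound 2 and compound 4 together at the weaker end of the numbers and no step among the four compounds being large. The compounds shown offer no independent measurement that would explain why these groups differ.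

From the compounds shown here alone, the groups compared at this carbon are limited to phenyl, its chloro and methyl forms, and naphthalen-1-yl, so it remains open how an amine, a carboxylic acid or a methoxy on the ring would read in this assay. Also open, going by these compounds, is whether a longer chain between the sulfur and the ring would move the number further in either direction.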